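This account rests on a few compounds, and the source may have more. Where it says the series, first, only, none or still open, it means among the compounds named here.

Three measured compounds share a core. In a functional assay on MCF-A cells (Homo sapiens) for cytotoxicity (on this read-out higher numbers stand for weaker inhibition of growth and lower numbers for stronger inhibition of growth), compound 1 `COc1ccc(C2=C(c3ccc(SC)cc3)CC3CCCN3C2=O)cc1Br` gives 6000 nM and compound 2 `COc1ccc(C2=C(c3ccc(SC)cc3)CC3CCCN3C2=O)cc1` gives 5000 nM. These two cannot be told apart, as the step is a 1.2-fold lower number from compound 1 to compound 2 (0.08 log units; within the scatter). Compound 3 `CSc1ccc(C2=C(c3ccc(O)cc3)C(=O)N3CCCC3C2)cc1` gives > 100000 nM in this assay, and this is a limit of the assay, not a number.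

Compound 4 `CSc1ccc(C2=C(c3ccc(OCC4CO4)cc3)C(=O)N3CCCC3C2)cc1` differs from compound 3 in one place: (oxiran-2-yl)methyl in place of hydrogen on an oxygen on an aromatic ring. There, (oxiran-2-yl)methyl stands in place of hydrogen on an oxygen on an aromatic ring. The closest measured change happens at that same oxygen, where a methyl gives way to hydrogen, and it is large: an at least 20-fold higher number from compound 2 to compound 3 (1.30 log units; beyond the scatter). The change an at least 16-fold higher number from compound 1 to compound 3 (1.22 log units; beyond the scatter) is also large and points the same way.

Putting a group back on that oxygen should therefore reverse the direction, towards a lower number and stronger inhibition of growth. However, (oxiran-2-yl)methyl is not methyl, so the size remains uncertain. The expected change is an at least 12-fold lower number from compound 3 to compound 4 (1.09 log units; beyond the scatter). For compound 4 the estimated value is 8000 nM, with an expected range from 1500 nM to 40000 nM.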

Compound 4, concentration for 50% growth inhibition: 10000 nM
Compound 4: middle estimate off by 1.3-fold (0.10 log units), on the low side; the measured number falls inside the stated range.
By their numbers in this assay, from the lowest: compounds 2, 1 and 4 (each within the scatter of the next). At a limit, above all of these: compound 3.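

Methyl is not the only group on this oxygen that goes with stronger inhibition of growth than a free hydroxy: in this assay there is an at least 10-fold lower number from compound 3 to compound 4 (1.00 log units; beyond the scatter). The larger (oxiran-2-yl)methyl also cannot be told apart from methyl, with a 2.0-fold higher number from compound 2 to compound 4 (0.30 log units; within the scatter), so adding oxiran-2-yl to the chain leaves no change that can be read beyond the scatter. Compound 3 stands at a limit, not a number, so the first step has no exact size: the limit of > 100000 nM in this assay, at which 1 of the 4 values shown sits.

Going by these compounds, it remains open whether the three-membered ring plays any part in this result, or whether simply capping the oxygen is enough. A longer plain chain such as butyl, or a chain ending in an amine, on the same oxygen could help separate these two readings.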